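From aryl carbonyl to phenoxy carbonyl on the shared core

A few compounds are considered here, and "the series" means these few. Any claim that something is new, unique, unknown or untested is made for them only; others in the source may bear on it.

In a functional assay on KB cells (Homo sapiens) for cytotoxicity (a lower number here means a stronger inhibitor, a higher number a weaker inhibitor), compound 1 `COc1ccc(S(=O)(=O)N2CCc3cccc(NS(=O)(=O)c4ccc(F)cc4)c32)cc1` gives 1200 nM and compound 2 `COc1ccc(S(=O)(=O)N2CCc3cccc(NC(=O)c4cccs4)c32)cc1` gives 47 nM. Compound 3 `COC(=O)c1ccc(C(=O)Nc2cccc3c2N(S(=O)(=O)c2ccc(OC)cc2)CC3)cc1` gives 376 nM, the middle of the three numbers, closer to compound 1 than to compound 2.

Compound 4 `COc1ccc(S(=O)(=O)N2CCc3cccc(NC(=O)Oc4ccccc4)c32)cc1` differs from compound 3 at one place, with phenoxy in place of 4-(methoxycarbonyl)phenyl on a carbonyl carbon.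

Within the data shown here, the closest precedent is the change on that same carbonyl carbon, an 8.0-fold higher number from compound 2 to compound 3 (0.90 log units; beyond the scatter), a modest step. The step of a 26-fold lower number from compound 1 to compound 2 (1.41 log units; beyond the scatter) is large, but it concerns the sulfonyl-to-carbonyl exchange, which compound 4 does not reverse, so it bears only loosely. Among the measured compounds shown here, no measured compound carries phenoxy, so the direction is uncertain. A partial return toward compound 2 is expected, since removing 4-(methoxycarbonyl)phenyl undoes part of the change in an 8.0-fold higher number from compound 2 to compound 3 (0.90 log units; beyond the scatter).

The expected change is modest, at a 2.2-fold lower number from compound 3 to compound 4 (0.34 log units; beyond the scatter). The estimate for compound 4 is 170 nM, with an expected range of 45 nM to 650 nM.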

Compound 4, half-maximal inhibitory concentration: > 10000 nM
Compound 4 ended at the assay's limit; the forecaster's own chance of this, stated with the estimate: 5%; middle value at least 58-fold (1.76 log units) away from the limit.
By their numbers in this assay, from the lowest: compound 2; then compound 3; then compound 1. At a limit, above all of these: compound 4.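

In this assay compound 4 stands at a limit of the assay, not at a number: the limit of > 10000 nM in this assay, at which 1 of the 4 values shown sits.

Among these compounds, on this carbonyl carbon, the earlier compounds showed only an 8.0-fold higher number from compound 2 to compound 3 (0.90 log units; beyond the scatter), whereas phenoxy opens much wider gaps: an at least 26-fold higher number from compound 3 to compound 4 (1.42 log units; beyond the scatter) and an at least 210-fold higher number from compound 2 to compound 4 (2.32 log units; beyond the scatter). The choice of group on this carbon can therefore cost more than the earlier aryl change suggested, and phenoxycarbonyl on the nitrogen also compares poorly with (4-fluorophenyl)sulfonyl, an at least 8.3-fold higher number from compound 1 to compound 4 (0.92 log units; beyond the scatter).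

The compounds shown do not separate the oxygen of phenoxy from the aromatic ring it carries, and an unsubstituted phenyl or an anilino group on the same carbonyl carbon would address that directly. On these data alone, how far compound 4 lies past the limit also remains open, so these steps give only minimum sizes.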